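The source may report more compounds than this note shows. Statements on the series, on what has been measured and on what is new or still open speak of the compounds shown alone.

In an assay on isolated protein with Bile acid receptor (Homo sapiens) as the target (on this read-out higher numbers stand for an effect only at larger amounts of compound and lower numbers for an effect already at smaller amounts), compound 1 `COC(=O)/C=C/c1cccc(N(Cc2ccc(/C=C/c3ccccn3)cc2)C(=O)C2CCCCC2)c1` gives 309 nM. Compound 2 `COC(=O)/C=C/c1cccc(N(Cc2ccc(-c3ccc(C(C)(C)C)cc3)cc2)C(=O)C2CCCCC2)c1` gives 132 nM. Compound 3 `COC(=O)/C=C/c1cccc(N(Cc2ccc(/C=C/C(=O)OCc3ccccc3)cc2)C(=O)C2CCCCC2)c1` reaches only the limit of this assay, > 1000 nM.

Compound 3 thus stands at the limit rather than at a number, as recorded in the limit of > 1000 nM in this assay, at which 1 of the 3 values shown sits; it is the weakest of the three on what is shown. The step to compound 4 `COC(=O)/C=C/c1cccc(N(Cc2ccc(-c3cccc(C(C)=O)c3)cc2)C(=O)C2CCCCC2)c1` is 3-acetylphenyl in place of 2-(benzyloxycarbonyl)ethenyl on an aromatic carbon. Within the data shown here, two measured steps bear on it. The step of an at least 7.5-fold higher number from compound 2 to compound 3 (0.87 log units; beyond the scatter) went from an aryl group to the ester-bearing chain and raised the number; the step of an at least 3.2-fold higher number from compound 1 to compound 3 (0.51 log units; beyond the scatter) also ended at the limit. Compound 4 returns to an aryl group, so the step is expected to run the other way, toward a lower number in this assay. Since the 3-acetylphenyl of compound 4 is not the same aryl as in compound 2, the size remains uncertain. Compound 4 is therefore expected to show a step of an at least 4.0-fold lower number from compound 3 to compound 4 (0.60 log units; beyond the scatter). Compound 4 is estimated at 250 nM, within a range from 80 nM to 800 nM.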

Compound 4, half-maximal effective concentration: 227 nM
Compound 4: middle estimate off by 1.1-fold (0.04 log units), on the high side; the range from low to high includes it.
By their numbers in this assay, from the lowest: compounds 2, 4 and 1 (each within the scatter of the next, the first and the last beyond it). At a limit, above all of these: compound 3.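

In this assay, 3-acetylphenyl at this position gives an at least 4.4-fold lower number from compound 3 to compound 4 (0.64 log units; beyond the scatter), so a carbonyl-bearing group on this aromatic carbon does not by itself go with the result for compound 3. Replacing 4-(tert-butyl)phenyl with 3-acetylphenyl gives a 1.7-fold higher number from compound 2 to compound 4 (0.24 log units; within the scatter), and replacing 2-(pyridin-2-yl)ethenyl with it gives a 1.4-fold lower number from compound 1 to compound 4 (0.13 log units; within the scatter), so neither of these changes can be told apart from repeat measurement. Compound 3 alone remains a limit rather than a number, and its step to compound 4 is therefore only a bound: the limit of > 1000 nM in this assay, at which 1 of the 4 values shown sits.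

The compounds shown leave open whether a carboxylic acid in place of the benzyl ester on the ethenyl chain would read like compound 3 or like compound 1. They also leave open whether an amine in place of the acetyl on the phenyl ring would change the number.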